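Swapping benzyl for methylsulfonyl on the shared core

The source may hold more compounds than are shown below. What is called first, only, known or untested is meant among the compounds shown, and "the series" means these compounds.

In a functional assay on L1210 (1565) cells (Mus musculus) for cytotoxicity (on this read-out higher numbers stand for an effect only at larger amounts of compound and lower numbers for an effect already at smaller amounts), compound 1 (`c1ccc(COc2cc(-c3ccccc3)nc3ccccc23)cc1`) gives > 10 ug/mL, which is a limit of the assay and not a number. Two relatives give true numbers: compound 2 (`Oc1ccc2nc(-c3ccccc3)cc(O)c2c1`) gives 0.83 ug/mL, and compound 3 (`Oc1cc(-c2ccccc2)nc2cc(F)ccc12`) gives 0.16 ug/mL. Compound 4 (`CS(=O)(=O)Oc1cc(-c2ccccc2)nc2ccccc12`) carries methylsulfonyl in place of benzyl on an oxygen on an aromatic ring. For the measured compounds named here, no measured pair shows this change directly. Compound 3 at 0.16 ug/mL shows that a relative can act at small amounts, which supports an expected move towards lower numbers. The estimated change is an at least 2.5-fold lower number from compound 1 to compound 4 (0.39 log units; beyond the scatter), a moderate one. For compound 4 the expected value is 4 ug/mL, with an estimated range from 0.6 ug/mL to 25 ug/mL.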

Compound 4, half-maximal effective concentration: 6.04 ug/mL
Estimate against measurement, compound 4: 1.5-fold (0.18 log units) below; low and high end bracket the measured number.
By their numbers in this assay, from the lowest: compound 3; then compound 2; then compound 4. At a limit, above all of these: compound 1.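

With methylsulfonyl in place of benzyl on an oxygen on an aromatic ring, compound 4 gives a true number in this assay, so a read-out at this position becomes measurable. The step is an at least 1.6-fold lower number from compound 1 to compound 4 (0.21 log units; that floor lies within the scatter). Compound 1 gives > 10 ug/mL, which is a limit of the assay and not a number.

On these data alone, how large the step really is stays open because one of its two ends sits at a limit: the limit of > 10 ug/mL in this assay, at which 1 of the 4 values shown sits. Also open, as far as these compounds go, is how an acetyl group or a longer chain on this oxygen would compare.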